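The source may report more compounds than this note shows. Statements on the series, on what has been measured and on what is new or still open speak of the compounds shown alone.

In a functional assay on HL-60 cells (Homo sapiens) for antiproliferative activity, with a stated time of 72 h (on this read-out higher numbers stand for weaker inhibition and lower numbers for stronger inhibition), compound 1 `OC[C@H]1O[C@@H](n2cnc3c(NCc4ccc(F)cc4)ncnc32)[C@H](O)[C@@H]1O` gives 1200 nM, while compound 2 `OC[C@H]1O[C@@H](n2cnc3c(NCc4ccc(F)c(F)c4F)ncnc32)[C@H](O)[C@@H]1O` gives 13000 nM, the higher of the two numbers and so the weaker inhibition. Compound 3 `Cc1ccc(O)c(CNc2ncnc3c2ncn3[C@@H]2O[C@H](CO)[C@@H](O)[C@H]2O)c1` is not yet measured, and its change from compound 2 is 2-hydroxy-5-methylphenyl in place of 2,3,4-trifluorophenyl on a saturated chain carbon bound to a nitrogen on an aromatic ring. For the measured compounds named here, only one measured step bears on this: an 11-fold higher number from compound 1 to compound 2 (1.03 log units; beyond the scatter), a large rise that came with the 2,3,4-trifluorophenyl group. Going by the values given here, no measured compound carries 2-hydroxy-5-methylphenyl, so this guide is limited. Removing the 2,3,4-trifluorophenyl group should undo much of that rise, giving an expected step of a 5.2-fold lower number from compound 2 to compound 3 (0.72 log units; beyond the scatter), towards stronger inhibition. For compound 3 the estimated value is 2500 nM, with an expected range from 500 nM to 12000 nM.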

Compound 3, half-maximal inhibitory concentration: 15000 nM
Compound 3: middle estimate off by 6.0-fold (0.78 log units), on the low side; the measured number lies above the stated range.
By their numbers in this assay, from the lowest: compound 1; then compounds 2 and 3 (each within the scatter of the next).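

In this assay, 2-hydroxy-5-methylphenyl in place of 2,3,4-trifluorophenyl gives a 1.2-fold higher number from compound 2 to compound 3 (0.06 log units; within the scatter), so these two quite different groups cannot be told apart at this position. Set against the 4-fluorophenyl group, the same new group gives a 13-fold higher number from compound 1 to compound 3 (1.10 log units; beyond the scatter), which leaves compound 1 the strongest inhibitor of the three, with a second, fluorine-free group now also far weaker. Nothing on hand explains this result. Still open, going by these compounds, is whether plain phenyl or 4-chlorophenyl would match compound 1. Also open, on these data alone, is whether the hydroxy or the methyl of compound 3 matters on its own.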